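The source may hold more compounds than are shown below. What is called first, only, known or untested is meant among the compounds shown, and "the series" means these compounds.

Three compounds share one core and differ only in the ring attached to a nitrogen on an aromatic ring. Compound 1 `FC(F)(F)c1ccc(CSc2nc(Nc3ccccc3Cl)c3ccccc3n2)cc1` gives 20400 nM in a functional assay on PC-3 cells (Homo sapiens) for cytotoxicity, read by MTT assay, with a stated time of 72 h (on this read-out higher numbers stand for weaker inhibition and lower numbers for stronger inhibition), the highest of the three numbers, though its steps to both neighbours fall within the scatter. Compound 2 `FC(F)(F)c1ccc(CSc2nc(Nc3cccc(C(F)(F)F)c3)c3ccccc3n2)cc1` gives 12900 nM, and compound 3 `O=[N+]([O-])c1cccc(Nc2nc(SCc3ccc(C(F)(F)F)cc3)nc3ccccc23)c1` gives 13500 nM. Compound 4 `COc1cc(Nc2nc(SCc3ccc(C(F)(F)F)cc3)nc3ccccc23)cc(OC)c1` has not yet been measured; it differs from compound 1 by 3,5-dimethoxyphenyl in place of 2-chlorophenyl on a nitrogen on an aromatic ring.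

Within the data shown here, two measured steps bear on this change, since each swaps the same ring at the same place: a 1.6-fold lower number from compound 1 to compound 2 (0.20 log units; within the scatter), and a 1.5-fold lower number from compound 1 to compound 3 (0.18 log units; within the scatter). Among the measured compounds shown here, neither moved the number beyond the scatter, and no measured step involves a methoxy group, so the new ring has no direct precedent. On that basis the expectation for compound 4 is a step of a 1.4-fold lower number from compound 1 to compound 4 (0.13 log units; within the scatter), no larger than the scatter. Compound 4 is therefore estimated at 15000 nM, within a range from 6000 nM to 40000 nM.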

Compound 4, half-maximal inhibitory concentration: > 50000 nM
Compound 4: only a limit was reported (the forecaster's own chance of this, stated with the estimate: 10%); middle value at least 3.3-fold (0.52 log units) away from the limit.
By their numbers in this assay, from the lowest: compounds 2, 3 and 1 (each within the scatter of the next). At a limit, above all of these: compound 4.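

The reading for compound 4 is a limit of the assay and not a number: the limit of > 50000 nM in this assay, at which 1 of the 4 values shown sits. Even so, the ring on this nitrogen is not interchangeable: the earlier swaps stayed within the scatter, whereas 3,5-dimethoxyphenyl gives an at least 2.4-fold higher number from compound 1 to compound 4 (0.38 log units; beyond the scatter), an at least 3.7-fold higher number from compound 3 to compound 4 (0.56 log units; beyond the scatter) and an at least 3.8-fold higher number from compound 2 to compound 4 (0.58 log units; beyond the scatter), all beyond the scatter. A higher number means weaker inhibition, so this position responds to the choice of ring, and among the four rings shown only 3,5-dimethoxyphenyl stands apart, by an amount that remains unknown.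

The compounds shown leave open whether a single methoxy group would have the same effect as the pair. They also leave open how a ring carrying a hydroxyl group or an amine would read at this position.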